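Swapping Bromo for a Fluoroanilino Group on a Weak Antagonist

A few compounds are considered here, and "the series" means these few. Any claim that something is new, unique, unknown or untested is made for them only; others in the source may bear on it.

Three compounds have been measured in an in vitro assay on HEK-tsA201 cells for antagonist activity at Neuronal acetylcholine receptor; alpha4/beta2 (Homo sapiens), read by fluorescence and calcium flux; on this read-out higher numbers stand for weaker inhibition and lower numbers for stronger inhibition:

Compound 1, `CCOc1ccc(C(=O)Nc2cc(C)cc(C)n2)cc1`, gives 17100 nM.
Compound 2, `C=CCOc1ccc(C(=O)Nc2cccc(Br)n2)cc1`, gives 70100 nM.
Compound 3, `CCCOc1ccc(C(=O)Nc2cccc(Br)n2)cc1`, gives 80700 nM.

Compound 3 has the highest number of the three, but its gap to compound 2 lies within the scatter, so the two cannot be told apart; compound 1 gives a clearly lower number, beyond the scatter. Compound 4, `CCCOc1ccc(C(=O)Nc2cccc(Nc3cccc(F)c3)n2)cc1`, differs from compound 3 in one place: (3-fluorophenyl)amino in place of bromo on an aromatic carbon. Within the data shown here, the only measured step, a 1.2-fold higher number from compound 2 to compound 3 (0.06 log units; within the scatter), concerns the chain on the oxygen, not the group on the ring with nitrogen, so no measured step bears directly on this change. The spread between compound 1 and compound 3 shows that altering that ring does move the numbers, but in which direction for this change the data cannot say. Compound 4 is therefore expected near compound 3, with wide uncertainty, at 40000 nM (range 8000 nM to 200000 nM), which is an expected step of a 2.0-fold lower number from compound 3 to compound 4 (0.30 log units; within the scatter).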

Compound 4, half-maximal inhibitory concentration: > 100000 nM
Compound 4: only a limit was reported (the forecaster's own chance of this, stated with the estimate: 25%); at least 2.5-fold (0.39 log units) between middle value and limit.
By their numbers in this assay, from the lowest: compound 1; then compounds 2 and 3 (each within the scatter of the next). At a limit, above all of these: compound 4.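

In this assay compound 4 gives > 100000 nM, which is a limit of the assay and not a number. Among these compounds, the step reads an at least 1.2-fold higher number from compound 3 to compound 4 (0.09 log units; that floor lies within the scatter), so its true size is unknown, but this is the first measured change to the group next to the ring nitrogen: bromo gives way to the far larger (3-fluorophenyl)amino, with its extra aromatic ring and hydrogen-bond donor, and no gain in inhibition appears. Any further ranking of this change stops at the top of the readable range: the limit of > 100000 nM in this assay, at which 1 of the 4 values shown sits.

As far as these compounds go, it remains open whether a small group at this place, such as an amine or a methyl, would read differently from bromo. Also open, from the compounds shown here alone, is how a plain phenylamino group, without the fluorine, would compare with (3-fluorophenyl)amino.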